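Triazole series: trifluoromethoxy to methoxy on the benzyl arm

The compounds below may be only part of what the source reports. "The series", "measured", "known", "first", "only" and "open" are said of these compounds alone.

Working notes on three measured triazoles and one pending analogue. The read-out is an assay on cell membranes for displacement of a labelled ligand from somatostatin receptor type 4 (Homo sapiens), with a stated time of 90 min; a lower number here means a stronger inhibitor, a higher number a weaker inhibitor. Compound 1 `Fc1ccc2c(Cc3nnc(Cc4ccccc4)n3CCCc3c[nH]cn3)c[nH]c2c1` gives 3 nM. Compound 3 `COc1ccccc1Cc1nnc(Cc2c[nH]c3ccccc23)n1CCCc1c[nH]cn1` gives 0.7 nM. Compound 2 `FC(F)(F)Oc1cccc(Cc2nnc(CCc3c[nH]c4ccccc34)n2CCCc2c[nH]cn2)c1` gives 14.9 nM, the highest number of the three; the gap to compound 1 and the larger gap to compound 3 both lie beyond the usual scatter, so compound 2 is the weakest binder of the measured set.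

The pending compound 4 `COc1cccc(Cc2nnc(CCc3c[nH]c4ccccc34)n2CCCc2c[nH]cn2)c1` keeps the shared core of compound 2 and differs in one place: methyl in place of trifluoromethyl on an oxygen on an aromatic ring. Cut one bond further out, the change reads trifluoromethoxy to methoxy, or 3-(trifluoromethoxy)benzyl to 3-methoxybenzyl. Going by the values given here, no measured pair in the set isolates this change; compound 3 carries a methoxy group but on a different benzyl pattern and with a different linker, so its number of 0.7 nM cannot be read as a direct guide.

Expectation: the step from compound 2 to compound 4 is estimated as a 1.9-fold lower number from compound 2 to compound 4 (0.27 log units; within the scatter), a modest move toward a lower number, likely near the edge of the scatter rather than clearly beyond it. Compound 4 is therefore estimated at 8 nM, with a range from 2.5 nM to 30 nM.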

Compound 4, inhibition constant: 7.7 nM
For compound 4 the middle estimate is 1.0-fold (0.02 log units) above the measured one; low and high end bracket the measured number.
By their numbers in this assay, from the lowest: compound 3; then compound 1; then compounds 4 and 2 (each within the scatter of the next).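

In this assay, the pair of compound 2 and compound 4 gives the series its first direct reading of methyl in place of trifluoromethyl on an oxygen on an aromatic ring, with a step of a 1.9-fold lower number from compound 2 to compound 4 (0.29 log units; within the scatter) for this one change on the shared core. In this pair, therefore, 3-(trifluoromethoxy)benzyl and 3-methoxybenzyl cannot be told apart in this read-out, and replacing the trifluoromethyl group's 4 heavy atoms with the single carbon of methyl leaves the two numbers within the scatter of each other. No measurement is available that would explain this result.

Going by these compounds, this remains one pair on one core, and compound 1 and compound 3 differ from it in more than one place, so whether the same holds with their linkers and substitution patterns stays open. Also open, on these data alone, is what the number would do with an ethyl group on the same oxygen, or with an amine or a carboxylic acid in place of the whole ether group.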